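Chloro-to-methyl swap on the fused ring: lipophilicity notes

The source may report more compounds than this note shows. Statements on the series, on what has been measured and on what is new or still open speak of the compounds shown alone.

Measured so far in a physicochemical assay for lipophilicity, at pH 3; a lower number here means a more polar compound, a higher number a more lipophilic compound:
compound 1 `CC(C)Nc1nc(NCc2ccco2)c2ccc(Cl)cc2n1`: 2.51
compound 2 `CC(C)Nc1nc(NCc2ccco2)c2cc(Cl)ccc2n1`: 2.6
compound 3 `Cc1ccc2c(NCc3ccco3)nc(NC(C)C)nc2c1`: 1.58

Compounds 1 and 2 have the same atoms joined differently; the difference between the two cores is not broken down here. Compound 2 stands highest of the three numbers, with compound 1 within the scatter of it and compound 3 well apart. The change methyl in place of chloro on an aromatic carbon produced a number 0.93 log units lower from compound 1 to compound 3 (beyond the scatter). The same change, (methyl in place of chloro on an aromatic carbon), leads from compound 2 to the unmeasured compound 4 `Cc1ccc2nc(NC(C)C)nc(NCc3ccco3)c2c1`. Since the step occurs only once among the measured pairs, the expectation rests on that single observation: a step of about a number 0.93 log units lower from compound 2 to compound 4 (beyond the scatter) is expected in this assay because of a number 0.93 log units lower from compound 1 to compound 3 (beyond the scatter). Compound 4 is therefore estimated at 1.67, with a likely range from 1.3 to 2.05.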

Compound 4, distribution coefficient: 1.55
The estimate for compound 4 lay 0.12 log units above the measured number; low and high end bracket the measured number.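

In this assay methyl in place of chloro on an aromatic carbon gives a number 1.05 log units lower from compound 2 to compound 4 (beyond the scatter) and on the other core gives a number 0.93 log units lower from compound 1 to compound 3 (beyond the scatter) so the change points the same way on both cores, with each step beyond the scatter. This rests on one pair per core and shows only that the direction carries between these two cores, not that it holds on any further core or for any other group. Nothing shown here explains the fall in the number on either core.

Open, from the compounds shown here alone, is how other groups in the same place would compare with chloro and methyl, for example an amine, a carboxylic acid or a longer chain. Going by these compounds, whether any such group would give a similar step on both cores also remains open.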